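The source may hold more compounds than are shown below. What is called first, only, known or untested is meant among the compounds shown, and "the series" means these compounds.

In a functional assay on A-375 cells (Homo sapiens) for inhibition, read by MTT assay, with a stated time of 120 h (a higher number here means a weaker inhibitor, a lower number a stronger inhibitor), compound 2 `CNC(=O)/C=C/c1ccc(NC(=O)Nc2ccc(Cl)c(C(F)(F)F)c2)cc1` gives 20900 nM, and compound 1 `CC(NC(=O)/C=C/c1ccc(NC(=O)Nc2ccc(Cl)c(C(F)(F)F)c2)cc1)c1ccccc1` gives 20800 nM, level with it within the scatter. Compound 3 `CC1CN(C(=O)/C=C/c2ccc(NC(=O)Nc3ccc(Cl)c(C(F)(F)F)c3)cc2)CC(C)O1` reads > 50000 nM, which is a limit of the assay. Compound 4 `CNC(=O)C#Cc1ccc(NC(=O)Nc2ccc(Cl)c(C(F)(F)F)c2)cc1` differs from compound 2 in one place: 2-(methylcarbamoyl)ethynyl in place of 2-(methylcarbamoyl)ethenyl on an aromatic carbon. The measured steps bear on it only indirectly, since they change the group on the carbonyl carbon and leave the ethenyl unit untouched: a 1.0-fold higher number from compound 1 to compound 2 (0.00 log units; within the scatter), and an at least 2.3-fold higher number from compound 2 to compound 3 (0.37 log units; beyond the scatter). The expectation therefore rests on compound 2 at 20900 nM, and no step beyond the scatter is expected in this assay. The expected step is a 1.2-fold lower number from compound 2 to compound 4 (0.06 log units; within the scatter). For compound 4 the estimated value is 18000 nM, with an expected range of 6000 nM to 50000 nM.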

Compound 4, half-maximal inhibitory concentration: > 50000 nM
Compound 4 ended at the assay's limit; the forecaster's own chance of this, stated with the estimate: 20%; middle value at least 2.7-fold (0.44 log units) away from the limit.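

In this assay, for the compounds shown here, the unit on the aromatic carbon proves not to be neutral: the change to 2-(methylcarbamoyl)ethynyl gives an at least 2.3-fold higher number from compound 2 to compound 4 (0.37 log units; beyond the scatter), whereas the earlier steps touched only the group on the carbonyl carbon. Compound 4 gives > 50000 nM, which is a limit. Readable values remain only for compound 1 and compound 2, and how far compound 4 lies beyond them cannot be told: the limit of > 50000 nM in this assay, at which 2 of the 4 values shown sit.

Open, going by these compounds, is how a saturated ethyl linker carrying the same methyl amide would read in this assay. On these data alone, a carboxylic acid in place of the methyl amide on the ethenyl unit is equally open.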